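Chloro to methyl: an expected cytotoxicity step

This account rests on a few compounds, and the source may have more. Where it says the series, first, only, none or still open, it means among the compounds named here.

Measured so far:
Compound 1, `COc1cc(-c2nnc(SCc3ccc(C)cc3)o2)ccc1O`: 549000 nM
Compound 2, `COc1cc(-c2nnc(SCc3ccc(Cl)cc3)o2)ccc1O`: 480000 nM
Compound 3, `COc1cc(-c2nnc(SCc3ccccc3Cl)o2)ccc1O`: 564000 nM

Three compounds share one core and differ only in the group on the saturated chain carbon bound to a sulfur, and all three were read in an ADME assay on cells (Mus musculus, strain BALB/c) for cytotoxicity, read by MTT assay, with a stated time of 24 h; on this read-out lower numbers stand for higher toxicity in this test and higher numbers for lower toxicity in this test. Compound 2 and compound 3 hold the same atoms joined differently: 2-chlorophenyl in place of 4-chlorophenyl on a saturated chain carbon bound to a sulfur. Compound 1 differs from compound 2 by methyl in place of chloro on an aromatic carbon, a change that gave a 1.1-fold higher number from compound 2 to compound 1 (0.06 log units; within the scatter).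

Compound 4, `COc1cc(-c2nnc(SCc3ccccc3C)o2)ccc1O`, is not yet measured in this assay. It differs from compound 3 by methyl in place of chloro on an aromatic carbon. This is the same kind of change as that from compound 2 to compound 1, but there the place is para to a large group and here it is ortho to a large group. Because a 1.1-fold higher number from compound 2 to compound 1 (0.06 log units; within the scatter) stayed within the scatter, the expected step is a 1.1-fold higher number from compound 3 to compound 4 (0.03 log units; within the scatter). Compound 4 is estimated at 600000 nM, between 350000 nM and 1000000 nM.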

Compound 4, half-maximal cytotoxic concentration: 592000 nM
Compound 4: the middle estimate sits 1.0-fold (0.01 log units) above what was measured, and the stated range covers the measured number.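

Methyl in place of chloro on an aromatic carbon, here ortho to a large group, gave a 1.0-fold higher number from compound 3 to compound 4 (0.02 log units; within the scatter), and in this assay this agrees with the earlier case: the same change on two cores in this assay, a 1.1-fold higher number (0.06 log units; within the scatter) from compound 2 to compound 1 and a 1.0-fold higher number (0.02 log units; within the scatter) from compound 3 to compound 4, 1.1-fold (0.04 log units) apart, within the scatter of two such steps The two wider swaps, a 1.2-fold higher number from compound 2 to compound 4 (0.09 log units; within the scatter) and a 1.1-fold higher number from compound 1 to compound 4 (0.03 log units; within the scatter), also stay within the scatter. The change therefore carried between these two cores without a measurable shift in the number, but this does not show how it would behave on a core where it moved the number, or on any other core.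

The compounds shown leave open whether an amine, a carboxylic acid or a longer chain in place of the methyl or chloro would move the number at all. They also leave open which part of the shared core, if any, governs the read-out.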